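Adding a Fluorine to the Anilide Ring of Compound 3

The compounds below may be only part of what the source reports. "The series", "measured", "known", "first", "only" and "open" are said of these compounds alone.

Among the measured compounds shown here, compound 3, whose structure is `COc1ccn2c(-c3ccc(NC(=O)c4ccc([N+](=O)[O-])o4)cc3)cnc2c1`, gives the lowest number of the three compounds measured so far in an ADME assay on microsomes from liver (Homo sapiens) for metabolic stability (on this read-out higher numbers stand for fast clearance and lower numbers for slow clearance), at 74.2 mL.min-1.g-1. Compound 2, `O=C(Nc1ccc(-c2cnc3ccccn23)cc1)c1ccc([N+](=O)[O-])o1`, sits close to it with 85.1 mL.min-1.g-1, and the gap a 1.1-fold lower number from compound 2 to compound 3 (0.06 log units; within the scatter) carries no real weight. Compound 1, `CC(=O)N1CC=C(c2ccn3c(-c4ccc(NC(=O)c5ccc([N+](=O)[O-])o5)cc4)cnc3c2)CC1`, gives 156 mL.min-1.g-1; the step of a 2.1-fold lower number from compound 1 to compound 3 (0.32 log units; beyond the scatter) is a modest one, while a 1.8-fold lower number from compound 1 to compound 2 (0.26 log units; within the scatter) stays inside the usual noise.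

Compound 4, `COc1ccn2c(-c3ccc(NC(=O)c4ccc([N+](=O)[O-])o4)cc3F)cnc2c1`, differs from compound 3 by a single change: fluoro in place of hydrogen on an aromatic carbon. For the measured compounds named here, none of the measured steps touches this part of the molecule; all three concern the other end of the shared core. Going by the values given here, the only guidance is indirect: the step from compound 2 to compound 3, a small change in substituent elsewhere, produced no movement beyond the scatter, and even the larger swap from compound 1 to compound 3 moved the number only modestly. A single fluorine added to an aromatic ring is a smaller alteration than either, so no shift beyond the scatter is expected in this assay.

For compound 4 the expected value is 70 mL.min-1.g-1, with a range of 40 mL.min-1.g-1 to 120 mL.min-1.g-1, which means an expected step of a 1.1-fold lower number from compound 3 to compound 4 (0.03 log units; within the scatter).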

Compound 4, intrinsic clearance in microsomes: 81.6 mL.min-1.g-1
Beside the measured number, compound 4's estimate is 1.2-fold (0.07 log units) below it; the measured number falls inside the stated range.
By their numbers in this assay, from the lowest: compounds 3, 4, 2 and 1 (each within the scatter of the next, the first and the last beyond it).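

On this assay, fluoro in place of hydrogen on an aromatic carbon, ortho to a large group and meta to a large group, gives a 1.1-fold higher number from compound 3 to compound 4 (0.04 log units; within the scatter). This is the only step shown that touches this ring of carbon only, as the earlier steps all concern the other end of the shared core, so it provides the first direct reading at this position: here, a single fluorine leaves the clearance number unchanged within the usual scatter. No measurement shown bears on why the number holds steady when this group enters.

The compounds shown leave open whether a different group at this same position, such as chloro, methyl or an amine, would move the number beyond the scatter, or whether only a group as small as a fluorine leaves it in place. They also leave open whether fluoro would read the same on another carbon of this ring, or when placed on compound 1 or compound 2 rather than on compound 3.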